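Notes on the step from compound 2 to compound 3

The source may report more compounds than this note shows. Statements on the series, on what has been measured and on what is new or still open speak of the compounds shown alone.

- compound 1 `CCC(CC)O[C@@H]1C=C(C(=O)O)C[C@H](NCc2ccc(OC)cc2)[C@H]1NC(C)=O` gives > 200000 nM as a limit
- compound 2 `CCC(CC)O[C@@H]1C=C(C(=O)O)C[C@H](NCc2ccc(-c3ccc(SC)cc3)cc2)[C@H]1NC(C)=O` gives > 200000 nM as a limit

In an ADME assay on cells (Fibroblast, Gallus gallus) for cytotoxicity, read by CCK-8 assay, with a stated time of 48 h (a higher number here means that more compound is tolerated, a lower number that less compound is tolerated), compound 2 stands at > 200000 nM as a limit, so its position is not a number. Going by the values given here, the two measured compounds share the limit of > 200000 nM in this assay, at which 2 of the 2 values shown sit, as their only evidence. Compound 3 `CCC(CC)O[C@@H]1C=C(C(=O)O)C[C@H](NCc2ccc(-c3cc4ccccc4s3)cc2)[C@H]1NC(C)=O` differs from compound 2 by 1-benzothiophen-2-yl in place of 4-(methylsulfanyl)phenyl on an aromatic carbon and keeps the rest of the core of compound 1. Among the compounds with values here, the single measured step, a step that the two limits leave unreadable from compound 1 to compound 2, gives no size to carry over, although it also replaces a group on an aromatic carbon. No step beyond the scatter is therefore expected in this assay, and no direction can be given. The expected move is a number no higher from compound 2 to compound 3 (the limit leaves the size open) and nothing larger. For compound 3 the estimated value is 200000 nM with an expected range from 100000 nM to 300000 nM as its ends.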

Compound 3, half-maximal cytotoxic concentration: > 200000 nM
Compound 3: no number, only a limit; the forecaster's own chance of this, stated with the estimate: 85%; the middle value lies on the limit itself.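

Compound 3 gives > 200000 nM in this assay, a limit and not a number, so no step among compound 1, compound 2 and compound 3 can be read: the limit of > 200000 nM in this assay, at which 3 of the 3 values shown sit.

The compounds shown leave open whether methoxy, 4-(methylsulfanyl)phenyl and 1-benzothiophen-2-yl differ at all in this assay.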